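The compounds below may be only part of what the source reports. "The series", "measured", "known", "first", "only" and "open" are said of these compounds alone.

Measured so far:
compound 1 `COc1cc(C(=O)c2sc(-c3ccc([N+](=O)[O-])cc3)cc2N)cc(OC)c1OC` — 100 nM
compound 2 `COc1cc(C(=O)c2sc(-c3cccc([N+](=O)[O-])c3)cc2N)cc(OC)c1OC` — 11 nM

In a functional assay on L1210 cells (Mus musculus) for antiproliferative activity (a higher number here means a weaker inhibitor, a lower number a stronger inhibitor), compound 1 gives the highest of the two numbers; the nearest is compound 2, reached by a 9.1-fold lower number from compound 1 to compound 2 (0.96 log units; beyond the scatter).

Compound 3 `COc1ccc(-c2cc(N)c(C(=O)c3cc(OC)c(OC)c(OC)c3)s2)cc1` differs from compound 1 as follows: methoxy in place of nitro on an aromatic carbon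

Within the data shown here, the only measured step, a 9.1-fold lower number from compound 1 to compound 2 (0.96 log units; beyond the scatter), moves the nitro to another position on the same aromatic carbon framework and keeps the group; it does not show what removing the nitro and installing a methoxy at the original position does. The step from compound 1 to compound 3 is therefore a new one within the series, with nothing to carry from compound 2 beyond the observation that the shared core tolerates a change at this end of the molecule.

Among the measured compounds shown here, with no direct precedent, compound 3 is expected near compound 1, a 1.2-fold higher number from compound 1 to compound 3 (0.08 log units; within the scatter), and the estimate for compound 3 in this assay is 120 nM within 25 nM to 600 nM.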

Compound 3, half-maximal inhibitory concentration: 45 nM
Estimate against measurement, compound 3: 2.7-fold (0.43 log units) above, and the stated range covers the measured number.
By their numbers in this assay, from the lowest: compound 2; then compound 3; then compound 1.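

In this assay, replacing 4-nitrophenyl with 4-methoxyphenyl gives a measurable gain (a 2.2-fold lower number from compound 1 to compound 3 (0.35 log units; beyond the scatter)), so the nitro is not required at this place, para to a large group, and a group with no nitrogen is accepted there. Compound 3 still falls short of the 3-nitrophenyl analogue (a 4.1-fold higher number from compound 2 to compound 3 (0.61 log units; beyond the scatter)), so this exchange of group does not match the gain from moving the nitro (a 9.1-fold lower number from compound 1 to compound 2 (0.96 log units; beyond the scatter)). Nothing on hand explains either result.

The compounds shown do not reveal whether methoxy would respond to a change of ring position as nitro does. Methoxy appears at only one place. Going by these compounds, how an amine or a carboxylic acid on the same phenyl would compare with nitro and methoxy also remains open.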